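The compounds below may be only part of what the source reports. "The series", "measured", "known", "first", "only" and "open" are said of these compounds alone.

For the measured compounds named here, in a functional assay on UO-31 cells (Homo sapiens) for inhibition, read by sulforhodamine B assay, with a stated time of 48 h (a lower number here means a stronger inhibitor of growth, a higher number a weaker inhibitor of growth), compound 2 `COc1cc(-c2nn(-c3cccc(NC(=O)c4ccc(Cl)c(C(F)(F)F)c4)c3)cc2-c2ccncc2)ccc1Cl` gives 267 nM, the lowest of the two numbers so far, while compound 1 `COc1cc(-c2nn(-c3cccc(NC(=O)Nc4cccc(C(F)(F)F)c4)c3)cc2-c2ccncc2)ccc1Cl` gives 702 nM. Going by the values given here, the one measured step, a 2.6-fold lower number from compound 1 to compound 2 (0.42 log units; beyond the scatter), is modest and beyond the scatter. Compound 3 `COc1cc(-c2nn(-c3cccc(NC(=O)c4ccccc4)c3)cc2-c2ccncc2)ccc1Cl` carries phenyl in place of 4-chloro-3-(trifluoromethyl)phenyl on a carbonyl carbon. That step from compound 1 to compound 2 bears on the new change only loosely, as it altered the whole group on the carbonyl carbon rather than the ring substituents alone. A weaker inhibition is expected for compound 3, a step of about a 3.7-fold higher number from compound 2 to compound 3 (0.57 log units; beyond the scatter). Compound 3 is estimated at 1000 nM, within a range of 300 nM to 4000 nM.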

Compound 3, concentration for 50% growth inhibition: 638 nM
Estimate against measurement, compound 3: 1.6-fold (0.20 log units) above, and the stated range covers the measured number.
By their numbers in this assay, from the lowest: compound 2; then compounds 3 and 1 (each within the scatter of the next).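

In this assay, phenyl in place of 4-chloro-3-(trifluoromethyl)phenyl on the carbonyl carbon gives a weaker inhibitor (a 2.4-fold higher number from compound 2 to compound 3 (0.38 log units; beyond the scatter)), so the substituted ring outperforms the bare one at this position. Phenyl in place of (3-(trifluoromethyl)phenyl)amino on the same carbon leaves the number within the scatter (a 1.1-fold lower number from compound 1 to compound 3 (0.04 log units; within the scatter)), so these two groups are not separated here. No measured evidence accounts for either step.
From the compounds shown here alone, whether the chlorine or the trifluoromethyl carries the gain alone remains open. So does the reading of a ring bearing a methoxy group, an amine or a carboxylic acid on this carbonyl carbon.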